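The source may hold more compounds than are shown below. What is called first, only, known or untested is meant among the compounds shown, and "the series" means these compounds.

Among the measured compounds shown here, compound 2, whose structure is `COc1cc(/C=C/C(=O)c2cccc(-n3cc(-c4ccccc4)[nH]c3=O)c2)ccc1O`, is one of two compounds measured in a functional assay on NCI-H522 cells (Homo sapiens) for inhibition (a higher number here means a weaker inhibitor of growth, a lower number a stronger inhibitor of growth), and its number there is 2360 nM. The other compound, compound 1 with structure `COc1cc(/C=C/C(=O)c2cccc(-n3cc(-c4ccc(Cl)cc4)[nH]c3=O)c2)cc(OC)c1OC`, differs from it in more than one place, so no single change links the pair; in this assay compound 1 gives 4100 nM, and the two values lie within the scatter of each other, so neither compound can be called the stronger inhibitor on this evidence.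

Compound 3, with structure `COc1cc(/C=C/C(=O)c2cccc(-n3cc(-c4ccc(Cl)cc4)[nH]c3=O)c2)ccc1O`, has not yet been measured. It is built from compound 2 by one change: chloro in place of hydrogen on an aromatic carbon. The same 4-chlorophenyl group is already present in compound 1, but since compound 1 also carries a different substitution pattern on the other ring, nothing measured here isolates what the chloro alone contributes.

For the measured compounds named here, with no matching step among the measured compounds, the expected step of a 1.1-fold higher number from compound 2 to compound 3 (0.03 log units; within the scatter) is set small, in no particular direction, and not beyond the scatter. Compound 3 is therefore estimated at 2500 nM in this assay, with a plausible range from 1000 nM to 6500 nM.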

Compound 3, concentration for 50% growth inhibition: 2360 nM
For compound 3 the middle estimate is 1.1-fold (0.03 log units) above the measured one, within the range that was stated.
By their numbers in this assay, from the lowest: compounds 2, 3 and 1 (each within the scatter of the next).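

Among the compounds shown here, the single change that compound 1 could not isolate can now be read on its own: in this assay, going from phenyl to 4-chlorophenyl gives no change at the digits printed from compound 2 to compound 3 (within the scatter). At this position, on an aromatic carbon para to a large group, putting chloro in place of hydrogen therefore leaves growth inhibition unchanged within the precision of the assay, and the activity of this series does not depend on the hydrogen found there in compound 2. The data at hand offer no measurement that would explain this result.

This is one step with one group, so it does not show that the position accepts any substituent, and a single small atom says little about how much room for change exists there. From the compounds shown here alone, whether an amine, a carboxylic acid or a longer chain on the same aromatic carbon would also leave the number in place remains open, as does whether the chloro change would read the same way in a test other than this growth assay on one cell line.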